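Extending the amino chain: from compound 2 to compound 3

The source may hold more compounds than are shown below. What is called first, only, known or untested is meant among the compounds shown, and "the series" means these compounds.

Compound 1 `CNc1nc(NCc2ccc(C(=O)Nc3ccc(F)cc3)cc2)c2ccccc2n1` gives 2900 nM in a functional assay on HCT-116 cells (Homo sapiens) for inhibition, read by luminescence and resazurin assay, with a stated time of 3 days; a lower number here means a stronger inhibitor, a higher number a weaker inhibitor.
Compound 2 `CCNc1nc(NCc2ccc(C(=O)Nc3ccc(F)cc3)cc2)c2ccccc2n1` gives 1900 nM in this assay.

Compound 2 holds the lower of the two numbers, yet the gap to compound 1, a 1.5-fold lower number from compound 1 to compound 2 (0.18 log units; within the scatter), lies within the scatter. Compound 3 `CCCNc1nc(NCc2ccc(C(=O)Nc3ccc(F)cc3)cc2)c2ccccc2n1` differs from compound 2 by methyl in place of hydrogen on a saturated chain carbon, two bonds along the chain from a nitrogen on an aromatic ring. Within the data shown here, the one step that bears on this change is that same chain lengthening, which stayed within the scatter, so no step beyond the scatter is expected in this assay for compound 3, at most a slight shift toward a lower number, a 1.3-fold lower number from compound 2 to compound 3 (0.10 log units; within the scatter). Compound 3 is therefore estimated at 1500 nM, with a range from 700 nM to 3200 nM.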

Compound 3, half-maximal inhibitory concentration: 1500 nM
For compound 3 middle estimate and measured number coincide at the digits printed, and the stated range covers the measured number.
By their numbers in this assay, from the lowest: compounds 3, 2 and 1 (each within the scatter of the next).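

The change from ethylamino to propylamino gives a 1.3-fold lower number from compound 2 to compound 3 (0.10 log units; within the scatter) in this assay, and the wider span across the chain gives a 1.9-fold lower number from compound 1 to compound 3 (0.29 log units; within the scatter). Even with the added carbons, the chain at this position therefore shows no step beyond the scatter, and the three compounds establish no order among themselves. No measurement offers an explanation for this flat result.

Open, going by these compounds, is whether a longer chain such as butyl, a branched isopropyl group, or a chain ending in an amine or a carboxylic acid would move the number beyond the scatter.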